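Dichlorophenyl sulfonamide positional isomer: cytotoxicity outlook

The source may report more compounds than this note shows. Statements on the series, on what has been measured and on what is new or still open speak of the compounds shown alone.

Compound 1 `CCc1ccc(S(=O)(=O)N2CCC(N3CCC(C)CC3)CC2)cc1`: in an ADME assay on HCT-116 cells (Homo sapiens) for cytotoxicity, read by CellTiter-Glo, with a stated time of 72 h (a higher number here means a weaker inhibitor, a lower number a stronger inhibitor), compound 1 gives > 5000 nM, a limit of the assay.
Compound 2 `CC1CCN(C2CCN(S(=O)(=O)c3ccc(Cl)cc3Cl)CC2)CC1`: in this assay compound 2 gives > 5000 nM, likewise a limit.

Compound 2 stands only at a limit in this assay, and both measured values sit there (the limit of > 5000 nM in this assay, at which 2 of the 2 values shown sit), so the step that the two limits leave unreadable from compound 1 to compound 2 gives no readable size. Compound 3 `CC1CCN(C2CCN(S(=O)(=O)c3cc(Cl)cc(Cl)c3)CC2)CC1` differs from compound 2 by 3,5-dichlorophenyl in place of 2,4-dichlorophenyl on a sulfonyl sulfur. Among the compounds with values here, the one measured step concerns the same sulfonyl sulfur but is unreadable, so no step beyond the scatter can be expected in this assay; another limit is the likelier outcome. Compound 3 is estimated at 8000 nM, between 3500 nM and 25000 nM. The expected step is a step that the limit leaves unreadable from compound 2 to compound 3.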

Compound 3, half-maximal inhibitory concentration: > 5000 nM
Compound 3 was reported as a limit (the forecaster's own chance of this, stated with the estimate: 85%); the middle value does not contradict the limit.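

No step can be read among compound 1, compound 2 and compound 3 in this assay, since each value is a limit: the limit of > 5000 nM in this assay, at which 3 of the 3 values shown sit.

From the compounds shown here alone, how the 4-ethylphenyl, 2,4-dichlorophenyl and 3,5-dichlorophenyl groups on the sulfonyl sulfur compare in this assay stays open.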